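Acetyl in place of butyl on the propargylamine nitrogen

The compounds below may be only part of what the source reports. "The series", "measured", "known", "first", "only" and "open" are said of these compounds alone.

Compound 1 `C#CCN(C)Cc1cn(-c2cc(NC(=S)NCC)ncn2)cn1` and compound 2 `C#CCN(CCCC)Cc1cn(-c2cc(NC(=S)NCC)ncn2)cn1` share one core and differ only at the amine nitrogen carrying the propargyl group. In an assay on isolated protein for inhibition of Amine oxidase [flavin-containing] A (Homo sapiens), read by fluorescence and Amplex Red, with a stated time of 15 min (on this read-out higher numbers stand for weaker inhibition and lower numbers for stronger inhibition), compound 1 gives > 50000 nM, which is a limit of the assay and not a number. In this assay compound 2 likewise gives > 50000 nM, again a limit and not a number. The step that the two limits leave unreadable from compound 1 to compound 2 therefore cannot be read; both values sit at the limit of > 50000 nM in this assay, at which 2 of the 2 values shown sit, so compound 2 stands at that limit with no measured number of its own.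

Compound 3 `C#CCN(Cc1cn(-c2cc(NC(=S)NCC)ncn2)cn1)C(C)=O` follows from compound 2 by the change (acetyl in place of butyl on an amine nitrogen). Going by the values given here, no measured step bears on this change: the only step recorded, propyl in place of hydrogen on the chain carbon bound to the amine nitrogen, is unreadable because both ends sit at the limit of > 50000 nM in this assay, at which 2 of the 2 values shown sit. With both neighbours at the limit, the expected step that the limit leaves unreadable from compound 2 to compound 3 is no readable change, and a further limit is the most likely outcome. Compound 3 is thus estimated at 60000 nM in this assay, within 10000 nM to 300000 nM.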

Compound 3, half-maximal inhibitory concentration: > 50000 nM
Compound 3 gave a limit, no number; the forecaster's own chance of this, stated with the estimate: 85%; the middle value is on the limit's open side.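

Compound 3 adds no readable step against compound 1 or compound 2 in this assay, since all three values are limits of the assay and not numbers: the limit of > 50000 nM in this assay, at which 3 of the 3 values shown sit.

The compounds shown leave open how methyl, butyl and acetyl on the amine nitrogen rank against one another, and what change to the shared core would bring a value inside the assay's range.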